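This account rests on a few compounds, and the source may have more. Where it says the series, first, only, none or still open, it means among the compounds named here.

In a functional assay on A549 cells (Homo sapiens) for antiproliferative activity, read by MTT assay, with a stated time of 72 h (a lower number here means a stronger inhibitor, a higher number a weaker inhibitor), compound 2 (`O=C1COc2ccc(-c3cnc(Cl)c(NS(=O)(=O)c4ccc(F)cc4)c3)cc2N1c1ccc(Cl)cc1`) gives 21600 nM as the higher of two numbers, which makes it the weaker inhibitor of the pair. Compound 1 (`COc1ncc(-c2ccc3c(c2)N(c2ccc(C)cc2)C(=O)CO3)cc1NS(=O)(=O)c1ccc(F)cc1`) gives 5870 nM as the lower number, a gap beyond the scatter. Compound 3 (`COc1ncc(-c2ccc3c(c2)N(c2ccc(Cl)cc2)C(=O)CO3)cc1NS(=O)(=O)c1ccc(F)cc1`) has methoxy in place of chloro on an aromatic carbon. For the measured compounds named here, no measured pair shows this change alone, but compound 1 (5870 nM) already carries methoxy there, though it also differs elsewhere. A drop beyond the scatter is therefore expected (a 2.9-fold lower number from compound 2 to compound 3 (0.46 log units; beyond the scatter)). The estimate for compound 3 is 7500 nM (expected range 2800 nM to 20000 nM).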

Compound 3, half-maximal inhibitory concentration: 8350 nM
For compound 3 the middle estimate is 1.1-fold (0.05 log units) below the measured one; measured number inside the range.
By their numbers in this assay, from the lowest: compounds 1 and 3 (each within the scatter of the next); then compound 2.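

In this assay, putting methoxy in place of chloro on the carbon next to the ring nitrogen gives a 2.6-fold lower number from compound 2 to compound 3 (0.41 log units; beyond the scatter) as a single change, so this position does respond to the swap. By contrast, chloro in place of methyl on an aromatic carbon gives a 1.4-fold higher number from compound 1 to compound 3 (0.15 log units; within the scatter) and separates the two compounds by nothing beyond the scatter. No measurement here explains either step. As far as these compounds go, whether an amine or a longer chain such as ethoxy at the first position would give a lower number remains open. So does whether the methoxy step would hold with a different group in place of the 4-fluorophenyl.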